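The source may report more compounds than this note shows. Statements on the series, on what has been measured and on what is new or still open speak of the compounds shown alone.

Among the compounds with values here, compound 1, `COC(=O)c1cccc(-c2cnc3[nH]cc(-c4cncnc4)c3c2)c1`, and compound 2, `N#Cc1cccc(-c2cnc3[nH]cc(-c4cccnc4)c3c2)c1`, share a fused bicyclic core and differ at two places, so no single step connects them. In an assay on isolated protein for inhibition of serine/threonine-protein kinase Nek1 (Homo sapiens), read by radiometric assay and 33P incorporation, in the presence of a further agent that is not named here (a higher number here means a weaker inhibitor, a lower number a stronger inhibitor), compound 1 gives 62.5 nM, and in this assay compound 2 gives 129 nM. Of the two numbers compound 1 holds the lower one, and the gap to compound 2 lies beyond the usual scatter, so compound 1 is the stronger inhibitor of the pair shown.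

Compound 3, `COC(=O)c1cccc(-c2cnc3[nH]cc(-c4ccncc4)c3c2)c1`, has not yet been measured in this assay. It differs from compound 1 in one respect: pyridin-4-yl in place of pyrimidin-5-yl on an aromatic carbon. The methyl ester on the pendant phenyl ring is kept. Within the data shown here, no step between two measured compounds isolates this exchange, so nothing in the data fixes its direction. Compound 3 is expected to land close to compound 1, with a step of a 1.0-fold lower number from compound 1 to compound 3 (0.02 log units; within the scatter) that need not exceed the scatter. For compound 3 the estimate in this assay is 60 nM, within a range from 20 nM to 200 nM.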

Compound 3, half-maximal inhibitory concentration: 140 nM
For compound 3 the middle estimate is 2.3-fold (0.37 log units) below the measured one; the range from low to high includes it.
By their numbers in this assay, from the lowest: compound 1; then compounds 2 and 3 (each within the scatter of the next).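

With the methyl ester kept, pyridin-4-yl in place of pyrimidin-5-yl on this aromatic carbon gives a 2.2-fold higher number from compound 1 to compound 3 (0.35 log units; beyond the scatter) in this assay, a modest step and the only comparison shown that changes this position alone. It shows that the position is not indifferent to which six-membered aromatic ring it carries, even though the heavy-atom count stays the same and only the ring's hetero atoms and hydrogen-bond acceptors differ. Nothing at hand explains the step.

This single pair cannot separate the loss of a ring nitrogen from the placement of the one that remains. It also leaves open whether a plain phenyl ring at this carbon would extend the step, and whether the step would hold with a carboxylic acid in place of the methyl ester.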